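Methyl on the pyrazole: a single-carbon step under study

A few compounds are considered here, and "the series" means these few. Any claim that something is new, unique, unknown or untested is made for them only; others in the source may bear on it.

Measured compounds:
compound 1, `Cc1nn(C)cc1Nc1nc(N)c2c(C#N)c(N3CCC[C@H]3C)n(C)c2n1`, 38 nM in an assay on isolated protein for inhibition of Leucine-rich repeat serine/threonine-protein kinase 2 (Homo sapiens), read by TR-FRET and LanthaScreen, with stated times of 50 min and 30 min, in the presence of a further agent that is not named here; on this read-out lower numbers stand for stronger inhibition and higher numbers for weaker inhibition
compound 2, `C[C@@H]1CCCN1c1c(C#N)c2c(N)nc(Nc3cnn(C)c3)nc2n1C`, 6 nM in this assay

Going by the values given here, compound 2 stands at the lowest of the two numbers measured so far; its nearest neighbour is compound 1, and the step between them, a 6.3-fold lower number from compound 1 to compound 2 (0.80 log units; beyond the scatter), lies beyond the scatter. Compound 3, `Cc1c(Nc2nc(N)c3c(C#N)c(N4CCC[C@H]4C)n(C)c3n2)cnn1C`, has not yet been measured. It differs from compound 2 in one place: methyl in place of hydrogen on an aromatic carbon.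

Among the compounds with values here, only one measured step bears on this change. Compound 1 also carries a methyl on the same five-membered aromatic ring, and the structures show it is not placed as in compound 3; removing that methyl, a 6.3-fold lower number from compound 1 to compound 2 (0.80 log units; beyond the scatter), gave a modest step. By analogy, adding a methyl to this ring in compound 3 is expected to raise the number somewhat, though the changed placement leaves the size uncertain. Compound 3 is therefore expected to show a 3.0-fold higher number from compound 2 to compound 3 (0.48 log units; beyond the scatter). The estimate for compound 3 is 18 nM, with a range from 5 nM to 60 nM.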

Compound 3, half-maximal inhibitory concentration: 75 nM
Compound 3: the middle estimate sits 4.2-fold (0.62 log units) below what was measured; the whole stated range lies below it.
By their numbers in this assay, from the lowest: compound 2; then compounds 1 and 3 (each within the scatter of the next).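

In this assay, methyl in place of hydrogen on the aromatic carbon next to the ring nitrogen gives a 13-fold higher number from compound 2 to compound 3 (1.10 log units; beyond the scatter), a large step, which shows that this single carbon is enough to lose most of what the 1-methyl-1H-pyrazol-4-yl group gives in this series. The placement of the methyl on the ring does not separate the two dimethyl groups: 1,5-dimethyl-1H-pyrazol-4-yl in place of 1,3-dimethyl-1H-pyrazol-4-yl gives a 2.0-fold higher number from compound 1 to compound 3 (0.30 log units; within the scatter), which lies within the scatter, so both methylated compounds stand apart from compound 2 and cannot be told apart from each other. Nothing in the data given accounts for the size of this step or for the likeness of the two placements.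

The compounds shown leave open whether the step belongs to the methyl itself or to any group on this carbon, and a fluorine or chlorine atom, an ethyl group or a hydroxymethyl group there would bear on that. They also leave open whether the same step would appear with a group other than the methylated pyrrolidine-bearing core shared by these three compounds.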